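Exchanging the Aryl Group on the Ring Nitrogen

The source may report more compounds than this note shows. Statements on the series, on what has been measured and on what is new or still open speak of the compounds shown alone.

Three compounds share one core and differ only in the group on an aromatic nitrogen. Compound 1 `CC1(C)[C@H]2CC[C@]1(C)N(Cc1cn(-c3cccc(C#N)c3)nn1)C(=O)C2` carries a 3-cyanophenyl and in a functional assay on PANC-1 cells (Homo sapiens) for inhibition, read by MTT assay, with a stated time of 24 h (on this read-out lower numbers stand for stronger inhibition and higher numbers for weaker inhibition), compound 1 gives 260 nM. Compound 2 `CC1(C)[C@H]2CC[C@]1(C)N(Cc1cn(-c3cccc(Cl)c3)nn1)C(=O)C2` carries a 3-chlorophenyl and gives 260 nM, while compound 3 `CC1(C)[C@H]2CC[C@]1(C)N(Cc1cn(-c3ccc(Br)cc3)nn1)C(=O)C2` carries a 4-bromophenyl and gives 200 nM. Compound 2 stands level with compound 1 at the digits shown, together the highest of the three numbers, yet the steps of no change at the digits printed from compound 1 to compound 2 (within the scatter), a 1.3-fold lower number from compound 1 to compound 3 (0.11 log units; within the scatter) and a 1.3-fold lower number from compound 2 to compound 3 (0.11 log units; within the scatter) all lie within the scatter. Compound 4 `COc1ccc(-n2cc(CN3C(=O)C[C@@H]4CC[C@@]3(C)C4(C)C)nn2)cc1` differs from compound 2 by 4-methoxyphenyl in place of 3-chlorophenyl on an aromatic nitrogen. Since every measured exchange at this position stayed within the scatter, no step beyond it is expected, and the estimated step is no change at the digits printed from compound 2 to compound 4 (within the scatter). Compound 4 is therefore expected to give 260 nM, within a range from 130 nM to 520 nM.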

Compound 4, half-maximal inhibitory concentration: 330 nM
Compound 4: middle estimate off by 1.3-fold (0.10 log units), on the low side; measured number inside the range.
By their numbers in this assay, from the lowest: compounds 3, 1, 2 and 4 (each within the scatter of the next).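

Swapping 3-chlorophenyl for 4-methoxyphenyl brings an oxygen and a hydrogen-bond acceptor onto the aromatic nitrogen, yet the result is a 1.3-fold higher number from compound 2 to compound 4 (0.10 log units; within the scatter), and the comparison with the nitrile-bearing compound gives a 1.3-fold higher number from compound 1 to compound 4 (0.10 log units; within the scatter). Even the widest gap in this set, a 1.7-fold higher number from compound 3 to compound 4 (0.22 log units; within the scatter), leaves the aryl exchanges undistinguished. No measurement shown here accounts for these small steps.

As far as these compounds go, whether an amine or a carboxylic acid on the aromatic ring would move the number beyond the scatter remains open. So does the effect of a longer alkyl chain in place of the aryl group.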